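Replacing a dimethylamino group with cyclopropylamino: expected solubility

A few compounds are considered here, and "the series" means these few. Any claim that something is new, unique, unknown or untested is made for them only; others in the source may bear on it.

Going by the values given here, compound 3 `Cc1cc(CCC#N)cc(C)c1Oc1cc(Nc2ccc(C#N)cc2)c(N)cc1CN(C)C` gives 260 ug/mL in a physicochemical assay for solubility, read by HPLC, with a stated time of 4 h, at pH 2, tested at 10 mg/mL (a lower number here means a less soluble compound, a higher number a more soluble compound), the highest of the three numbers so far. Compound 2 `Cc1cc(CCC#N)cc(C)c1Oc1cc(Nc2ccc(C#N)cc2)c(N)cc1C(=O)NC1CC1` gives 141 ug/mL in this assay, and compound 1 `CCNC(=O)c1cc(N)c(Nc2ccc(C#N)cc2)cc1Oc1c(C)cc(CCC#N)cc1C` gives 69.4 ug/mL in this assay. The step of a 3.7-fold higher number from compound 1 to compound 3 (0.57 log units; beyond the scatter) lies beyond the scatter, while the step of a 1.8-fold higher number from compound 2 to compound 3 (0.27 log units; within the scatter) does not. Compound 4 `Cc1cc(CCC#N)cc(C)c1Oc1cc(Nc2ccc(C#N)cc2)c(N)cc1CNC1CC1` differs from compound 3 by cyclopropylamino in place of dimethylamino on a saturated chain carbon bound to an aromatic carbon. The closest comparison among the measured steps is a 2.0-fold higher number from compound 1 to compound 2 (0.31 log units; beyond the scatter), where a cyclopropyl group also took the place of a small alkyl group on a nitrogen; that step was modest. The other steps concern the swap of an amide for an amine and say little about this change. A small upward step, or none beyond the scatter, is therefore expected, as a 1.2-fold higher number from compound 3 to compound 4 (0.09 log units; within the scatter). Compound 4 is expected to give about 320 ug/mL in this assay, within a range from 150 ug/mL to 650 ug/mL.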

Compound 4, solubility: 276 ug/mL
Beside the measured number, compound 4's estimate is 1.2-fold (0.06 log units) above it, within the range that was stated.
By their numbers in this assay, from the lowest: compound 1; then compounds 2, 3 and 4 (each within the scatter of the next).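

In this assay, cyclopropylamino in place of dimethylamino on a saturated chain carbon bound to an aromatic carbon gives a 1.1-fold higher number from compound 3 to compound 4 (0.03 log units; within the scatter) and so shows that this position accepts a three-membered ring and a hydrogen-bond donor with no change that can be told from the scatter. With (cyclopropylamino)methyl on the aromatic carbon, the comparison with the amides gives a 2.0-fold higher number from compound 2 to compound 4 (0.29 log units; within the scatter) and a 4.0-fold higher number from compound 1 to compound 4 (0.60 log units; beyond the scatter) as the two steps, and only the second lies beyond the scatter, the same outcome as for the steps from these two amides to compound 3. Nothing measured here gives a reason for these numbers.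

Still open, on these data alone, is how a larger ring amine such as morpholine or piperidine would fare on this carbon. A carboxylic acid on the longer chain of the same place also remains an open case.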